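The source may hold more compounds than are shown below. What is called first, only, known or untested is meant among the compounds shown, and "the series" means these compounds.

In an ADME assay on microsomes from liver (Mus musculus) for metabolic stability (a lower number here means slower removal, a higher number faster removal of the compound), compound 1 `CCn1nc(CC(=O)Nc2ccc(OC(F)(F)F)c(Cl)c2)c2ccccc2c1=O` gives 81.7 mL/min/kg and compound 2 `CC(C(=O)O)c1nn(Cc2cn3cc(OCC4CC4)c(Cl)cc3n2)c2ccccc2c1=O` gives 80 mL/min/kg, two values within the usual scatter of each other. Compound 3 `O=C(O)Cn1nc(Cc2nc3cc(F)c(OCC4CC4)cc3[nH]2)c2ccccc2c1=O` reads < 53.4 mL/min/kg, which is a limit of the assay and not a number. Among the measured compounds shown here, compound 2 therefore stands level with compound 1, and it is one of only two exact numbers available.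

The next compound to be read is compound 4 `C[C@@H](C(=O)O)c1nn(Cc2cn3cc(OCC4CC4)c(Cl)cc3n2)c2ccccc2c1=O`. The change from compound 2 is the two compounds have the same atoms and bonds; at least one stereo element is drawn with a configuration in one of them and without one in the other: 1 of 1 stereo elements differ; a stereocentre at a saturated chain carbon is drawn without a configuration in compound 2 and R in compound 4. The two compounds have the same atoms and bonds, and a stereocentre at a saturated chain carbon is drawn without a configuration in compound 2 and R in compound 4.

For the measured compounds named here, no measured pair isolates a change of this kind, so the expectation rests on compound 2 at 80 mL/min/kg. A step of a 1.0-fold lower number from compound 2 to compound 4 (0.01 log units; within the scatter) is expected to stay within the scatter of this assay, with no direction favoured. For compound 4, the estimated clearance is 78 mL/min/kg, with an expected range of 50 mL/min/kg to 115 mL/min/kg.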

Compound 4, clearance: < 55 mL/min/kg
Compound 4 ended at the assay's limit; the forecaster's own chance of this, stated with the estimate: 12%; middle value at least 1.4-fold (0.15 log units) from the limit.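

In this assay, compound 4 gives < 55 mL/min/kg, which is a limit of the assay and not a number. The series now holds a step that touches only the stereocentre at a saturated chain carbon, with atoms and bonds unchanged: an at least 1.4-fold lower number from compound 2 to compound 4 (0.16 log units; that floor lies within the scatter). The floor of that step lies within the scatter, so this pair alone does not establish a real difference between the undefined and the R drawing of this carbon.

On these data alone, how far the true value of compound 4 lies from its limit stays open, and so does the reading of the S configuration at the same carbon. Also open, as far as these compounds go, is whether a primary amide in place of the carboxylic acid on this chain would change the reading in this assay.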